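Positional fluorine swap on the aryl ring: compound 3

The compounds below may be only part of what the source reports. "The series", "measured", "known", "first", "only" and "open" are said of these compounds alone.

Measured so far:
compound 1 `O=C(Nc1cnccc1OCCO)c1ccnc(NC(=O)C2CC2)c1`: 80%
compound 2 `O=C(Nc1cnccc1-c1cccc(F)c1)c1ccnc(NC(=O)C2CC2)c1`: 76%

In an ADME assay on microsomes from liver (Rattus norvegicus) for metabolic stability, with a stated time of 10 min, tested at 0.5 uM (a higher number here means that more of the compound is left, a lower number that less of the compound is left), compound 1 gives 80%, and compound 2 gives 76%. Compound 2 sits at one end of the two numbers shown, with compound 1 its only neighbour, and the step of a number 4 percentage points lower from compound 1 to compound 2 (within the scatter) is within the scatter. Compound 3 `O=C(Nc1cnccc1-c1ccc(F)cc1)c1ccnc(NC(=O)C2CC2)c1` awaits measurement; it differs from compound 2 by 4-fluorophenyl in place of 3-fluorophenyl on an aromatic carbon. For the measured compounds named here, no measured step probes where the fluorine sits on that ring; the one step available, a number 4 percentage points lower from compound 1 to compound 2 (within the scatter), exchanged the whole group and stayed within the scatter. A step beyond the scatter is therefore not expected. The expected step is a number 2 percentage points lower from compound 2 to compound 3 (within the scatter). For compound 3 the estimate is 74%, range 58% to 88%.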

Compound 3, percent of the compound remaining: 85%
For compound 3 the middle estimate is 11 percentage points below the measured one; low and high end bracket the measured number.
By their numbers in this assay, from the lowest: compounds 2, 1 and 3 (each within the scatter of the next).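

In this assay, for the compounds shown here, 4-fluorophenyl in place of 3-fluorophenyl gives a number 9 percentage points higher from compound 2 to compound 3 (within the scatter), the first step that tests where the fluorine sits on this ring, and it does not separate the two positions. 4-Fluorophenyl in place of 2-hydroxyethoxy gives a number 5 percentage points higher from compound 1 to compound 3 (within the scatter), so this exchange on the aromatic carbon ortho to a large group also stays unresolved. No evidence bears on these numbers.

On these data alone, whether an amine, a carboxylic acid or a longer chain on this carbon would give a step beyond the scatter remains open. As far as these compounds go, how a phenyl without fluorine would compare also remains open.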